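The compounds below may be only part of what the source reports. "The series", "measured", "known", "first", "only" and "open" are said of these compounds alone.

Compound 1 `CN(C)c1ncnc2c1c(-c1ccoc1)cn2[C@@H]1O[C@H](CO)[C@@H](O)[C@H]1O` gives > 20000 nM in a functional assay on CEM-DNR-bulk cells (Homo sapiens), read by MTT assay, with a stated time of 72 h (on this read-out lower numbers stand for stronger inhibition and higher numbers for weaker inhibition), which is a limit of the assay and not a number.
Compound 2 `C#Cc1cn([C@@H]2O[C@H](CO)[C@@H](O)[C@H]2O)c2nc(C)nc(N)c12` gives 12600 nM.
Compound 3 `COc1nc(N)nc2c1c(-c1ccoc1)cn2[C@@H]1O[C@H](CO)[C@@H](O)[C@H]1O` gives > 20000 nM, again a limit of the assay.

Within the data shown here, compound 2 therefore holds the only number in the set; the two other values sit at the limit of > 20000 nM in this assay, at which 2 of the 3 values shown sit. The account follows the step from compound 2 to compound 4 `Cc1nc(N)c2c(-c3ccsc3)cn([C@@H]3O[C@H](CO)[C@@H](O)[C@H]3O)c2n1`, which has not yet been measured. The change is thiophen-3-yl in place of ethynyl on an aromatic carbon. Among the measured compounds shown here, no measured pair differing in a single place is available, so the size of this step cannot be read from a measured step. Compound 2 itself sits close to the limit, and both of the other compounds sit at that limit, so the expectation is that compound 4 loses activity by a modest step in this assay, that is a 1.7-fold higher number from compound 2 to compound 4 (0.24 log units; within the scatter), beyond the usual scatter but with a fair chance that only a limit is reported. Compound 4 is therefore estimated at 22000 nM, with a range from 7000 nM to 60000 nM.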

Compound 4, half-maximal inhibitory concentration: > 20000 nM
Compound 4: no number, only a limit; the forecaster's own chance of this, stated with the estimate: 55%; the middle value lies beyond the limit too.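

In this assay, among these compounds, this is the first change at this aromatic carbon that can be read as a step, and it can be read only as a floor: an at least 1.5-fold higher number from compound 2 to compound 4 (0.20 log units; that floor lies within the scatter). Compound 4 gives > 20000 nM, which is a limit of the assay and not a number. With thiophen-3-yl in place of ethynyl, the number that ethynyl gave on this core is therefore lost, and the true size of the step cannot be told because the read-out ends at a limit: the limit of > 20000 nM in this assay, at which 3 of the 4 values shown sit.

The compounds shown leave open whether a methyl group, an amine or a carboxylic acid on this same carbon would give a number in this assay. They also leave open whether any group here would give a lower number than ethynyl does in compound 2.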